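Extending the chain from a compound at the assay limit

A few compounds are considered here, and "the series" means these few. Any claim that something is new, unique, unknown or untested is made for them only; others in the source may bear on it.

In a functional assay on A549 cells (Homo sapiens) for antiproliferative activity, read by MTT assay, with a stated time of 72 h (a higher number here means a weaker inhibitor, a lower number a stronger inhibitor), compound 1 `CCCCCCCCCNC[C@@H]1OC[C@H](N)[C@H]1O` gives > 128000 nM, a limit of the assay and not a number. Compound 2 `CCCCCCCNC[C@@H]1OC[C@H](N)[C@H]1O` gives > 128000 nM in this assay, again only a limit. The standing of compound 2 is therefore (the limit of > 128000 nM in this assay, at which 2 of the 2 values shown sit), so it offers no true number as a starting point.

The next change, (butyl in place of hydrogen on a saturated chain carbon, seven bonds along the chain from an amine nitrogen), gives compound 3 `CCCCCCCCCCCNC[C@@H]1OC[C@H](N)[C@H]1O`. Among the compounds with values here, the only measured step at this place is a step that the two limits leave unreadable from compound 1 to compound 2, in which hydrogen replaces ethyl. That step has no readable size, so it sets no measure for the new change. Only a modest move toward stronger inhibition is expected in this assay, and a result that stays at the limit is quite possible. The expected step is an at least 2.1-fold lower number from compound 2 to compound 3 (0.32 log units; beyond the scatter). For compound 3 the estimated value is 60000 nM, with an expected range of 15000 nM to 128000 nM.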

Compound 3, half-maximal inhibitory concentration: 9650 nM
Compound 3: the middle estimate sits 6.2-fold (0.79 log units) above what was measured, outside the stated range (below it).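

Within the data shown here, compound 3 is the first compound here to give a true number, so this position on the chain now has a readable effect in this assay: butyl in place of hydrogen gives an at least 13-fold lower number from compound 2 to compound 3 (1.12 log units; beyond the scatter). Ethyl in place of hydrogen, nine bonds along the chain from an amine nitrogen, gives an at least 13-fold lower number from compound 1 to compound 3 (1.12 log units; beyond the scatter), so both shorter chains fall well short of the longest one. The step between those two shorter chains cannot be read, and the values for both are limits of the assay, not numbers: the limit of > 128000 nM in this assay, at which 2 of the 3 values shown sit.

Still open, from the compounds shown here alone, is whether a longer chain would lower the number further or lose the gain. Also open, going by these compounds, is whether a hydroxyl group or a phenyl ring at the far end of the chain would keep it.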